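The source may hold more compounds than are shown below. What is called first, only, known or untested is meant among the compounds shown, and "the series" means these compounds.

Working notes on the series. Of the compounds shown here, two have been measured in a functional assay on T47D cells (Homo sapiens) for inhibition, read by sulforhodamine B assay, with a stated time of 48 h; a higher number here means a weaker inhibitor of growth, a lower number a stronger inhibitor of growth. Compound 1 `NS(=O)(=O)c1ccc(Nc2nc(N/N=C/c3ccc(C(F)(F)F)cc3)nc(Nc3ccccc3)n2)cc1` gives 2480 nM in this assay. Compound 2 `Cc1nn(-c2ccccc2)cc1/C=N/Nc1nc(Nc2ccccc2)nc(Nc2ccc(S(N)(=O)=O)cc2)n1` gives 2140 nM in this assay. Of the two numbers compound 2 has the lowest, but the gap to compound 1 is small: the step of a 1.2-fold lower number from compound 1 to compound 2 (0.06 log units; within the scatter) stays within the scatter, so no order between the two can be read from it.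

Compound 3 `NS(=O)(=O)c1ccc(Nc2nc(N/N=C/c3ccccn3)nc(Nc3ccccc3)n2)cc1` is the next compound and is not yet measured. It differs from compound 2 in one place: pyridin-2-yl in place of 3-methyl-1-phenyl-1H-pyrazol-4-yl on a carbon with a double bond to nitrogen. Among the measured compounds shown here, only one measured step bears on this position, the step from compound 1 to compound 2, which exchanged the group on the same carbon with a double bond to nitrogen and moved the number by a 1.2-fold lower number from compound 1 to compound 2 (0.06 log units; within the scatter). That single step gives no sign that this position moves the number beyond the scatter, and nothing else in the measured pairs speaks to a pyridin-2-yl group.

For compound 3 the expected step in this assay is therefore a 1.1-fold higher number from compound 2 to compound 3 (0.03 log units; within the scatter), that is, no movement beyond the scatter. The estimate for compound 3 in this assay is 2300 nM, with a range from 900 nM to 6000 nM.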

Compound 3, concentration for 50% growth inhibition: 470 nM
The estimate for compound 3 lay 4.9-fold (0.69 log units) above the measured number, and the stated range ends above it.
By their numbers in this assay, from the lowest: compound 3; then compounds 2 and 1 (each within the scatter of the next).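

The place on a carbon with a double bond to nitrogen now responds in this assay: the earlier exchange there stayed within the scatter, but pyridin-2-yl gives a 4.6-fold lower number from compound 2 to compound 3 (0.66 log units; beyond the scatter) and a 5.3-fold lower number from compound 1 to compound 3 (0.72 log units; beyond the scatter) against the two groups it replaces. The step therefore appears from both 3-methyl-1-phenyl-1H-pyrazol-4-yl and 4-(trifluoromethyl)phenyl, two groups whose compounds stand within the scatter of each other, so the first measured step did not show the full reach of this position. The series holds no measurement that accounts for the lower number with pyridin-2-yl.

The compounds shown do not separate the ring nitrogen of pyridin-2-yl from the absence of any substituent on that ring, and a plain phenyl group or a pyridin-3-yl group at the same place would tell these two readings apart. Also open, on these data alone, is whether the step survives when the rest of the molecule changes, for instance with a morpholine in place of the anilino group on the shared core, or with a carboxylic acid in place of the sulfonamide.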